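Compound 2 without its aromatic methyl

The source may report more compounds than this note shows. Statements on the series, on what has been measured and on what is new or still open speak of the compounds shown alone.

In a functional assay on MDA-MB-231 cells (Homo sapiens) for antiproliferative activity, read by sulforhodamine B assay, with a stated time of 48 h (on this read-out higher numbers stand for weaker inhibition and lower numbers for stronger inhibition), compound 1 (`COc1cc(OC)c2sc(-c3ccc(N/C=C\C(=O)c4ccc(OC)c([N+](=O)[O-])c4)cc3)nc2c1`) gives 12900 nM and compound 2 (`COc1cc(OC)c2sc(-c3ccc(N/C=C\C(=O)c4cc(OC)c(OC)c(OC)c4)c(C)c3)nc2c1`) gives 13800 nM so compound 2 stands within the scatter of compound 1 and neither value can be ranked. Compound 3 (`COc1cc(OC)c2sc(-c3ccc(N/C=C\C(=O)c4cc(OC)c(OC)c(OC)c4)cc3)nc2c1`) has hydrogen in place of methyl on an aromatic carbon of compound 2 (hydrogen in place of methyl on an aromatic carbon). Going by the values given here, no measured pair isolates this change, so the expected 1.4-fold lower number from compound 2 to compound 3 (0.14 log units; within the scatter) is taken as none beyond the scatter, with no firm direction. The estimated value for compound 3 is 10000 nM (expected range 3000 nM to 28000 nM).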

Compound 3, half-maximal inhibitory concentration: 15800 nM
Compound 3: middle estimate off by 1.6-fold (0.20 log units), on the low side; the range from low to high includes it.
By their numbers in this assay, from the lowest: compounds 1, 2 and 3 (each within the scatter of the next).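

In this assay, hydrogen in place of methyl on the aromatic carbon (a 1.1-fold higher number from compound 2 to compound 3 (0.06 log units; within the scatter)) leaves compound 2 and compound 3 inseparable, so at this position methyl and hydrogen cannot be told apart. On the carbonyl carbon, 3,4,5-trimethoxyphenyl in place of 4-methoxy-3-nitrophenyl (a 1.2-fold higher number from compound 1 to compound 3 (0.09 log units; within the scatter)) likewise gives no readable difference. No supporting data bear on either result. Still open, from the compounds shown here alone, is whether an amine or a carboxylic acid on this aromatic carbon would move the number beyond the scatter.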